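Amide aryl swap in the triazole acetamide series

A few compounds are considered here, and "the series" means these few. Any claim that something is new, unique, unknown or untested is made for them only; others in the source may bear on it.

Measured compounds in a functional assay on MCF7 cells (Homo sapiens) for inhibition, read by MTT assay, with a stated time of 24 h; a higher number here means a weaker inhibitor, a lower number a stronger inhibitor:
- compound 1 `CCOC(=O)C1=Cc2ccccc2OC1(OCc1cc(-c2ccc(F)cc2F)no1)C(F)(F)F`: > 150000 nM (a limit, not a number)
- compound 2 `CCOC(=O)C1=Cc2ccccc2OC1(OCc1cn(CC(=O)Nc2cccc(Cl)c2)nn1)C(F)(F)F`: 11600 nM

Among the measured compounds shown here, compound 2 holds the only measured number in this assay, 11600 nM. Compound 1 reaches only a limit in this assay, > 150000 nM, as recorded in the limit of > 150000 nM in this assay, at which 1 of the 2 values shown sits. For the measured compounds named here, no pair of measured compounds differs in one place, so no measured step is available, and the two values together give no guide to the size of any change.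

Compound 3 `CCOC(=O)C1=Cc2ccccc2OC1(OCc1cn(CC(=O)Nc2ccc(OC)cc2)nn1)C(F)(F)F` differs from compound 2 by 4-methoxyphenyl in place of 3-chlorophenyl on an amide-type nitrogen. Going by the values given here, with no measured step to lean on, the expected change is none beyond the scatter, in either direction. Compound 3 is therefore estimated at 12000 nM in this assay, with a range from 4000 nM to 40000 nM. The expected step is a 1.0-fold higher number from compound 2 to compound 3 (0.01 log units; within the scatter), within the scatter.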

Compound 3, half-maximal inhibitory concentration: 28100 nM
The estimate for compound 3 lay 2.3-fold (0.37 log units) below the measured number; the measured number falls inside the stated range.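

The aryl group on the amide-type nitrogen now has its first measured step in this assay: 4-methoxyphenyl in place of 3-chlorophenyl gives a 2.4-fold higher number from compound 2 to compound 3 (0.38 log units; beyond the scatter) and moves the read-out beyond the scatter, though only modestly. This place in the series is therefore sensitive to the aryl group, and both aryl groups tested still give a measured number rather than a limit. Nothing measured here bears on what lies behind this step.

The swap replaces both the substituent and its ring position, so the two contributions remain unseparated; 3-methoxyphenyl or 4-chlorophenyl on the same nitrogen would divide them. Also open, on these data alone, is how the read-out responds when the aryl group gives way to a saturated ring such as cyclohexyl, or to a longer alkyl chain.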